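This account rests on a few compounds, and the source may have more. Where it says the series, first, only, none or still open, it means among the compounds named here.

Compound 1 `CC(CCC(=O)O)Cc1cccc(OCc2ccc3ccccc3n2)c1` is one of two compounds tested in a functional assay (lung) for inhibition, with Cavia porcellus as the target (a lower number here means a stronger inhibitor, a higher number a weaker inhibitor), and compound 1 gives 500 nM, the higher of the two numbers. Compound 2 `CCCC(CCC(=O)O)Cc1ccc(OCc2ccc3ccccc3n2)cc1` gives 30 nM in this assay, a gap that lies beyond the usual scatter. Compound 3 `c1cc(CCCCc2nnn[nH]2)cc(OCc2ccc3ccccc3n2)c1` has not yet been measured. It differs from compound 1 in one place: 3-(1H-tetrazol-5-yl)propyl in place of 3-carboxy-1-methylpropyl on a saturated chain carbon bound to an aromatic carbon. For the measured compounds named here, no measured pair shows this change, so the expected step from compound 1 to compound 3 is a 1.7-fold lower number from compound 1 to compound 3 (0.22 log units; within the scatter), small and uncertain. For compound 3 the estimated value in this assay is 300 nM, within 60 nM to 1500 nM.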

Compound 3, half-maximal inhibitory concentration: 105 nM
Compound 3: middle estimate off by 2.9-fold (0.46 log units), on the high side, and the stated range covers the measured number.
By their numbers in this assay, from the lowest: compound 2; then compound 3; then compound 1.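

In this assay, swapping 3-carboxy-1-methylpropyl for 3-(1H-tetrazol-5-yl)propyl on this saturated chain carbon bound to an aromatic carbon gives a 4.8-fold lower number from compound 1 to compound 3 (0.68 log units; beyond the scatter), so at this position a chain ending in a tetrazole can outperform the carboxy chain of compound 1. The change also removes the methyl branch, so this single step covers two differences at once. Nothing available explains the step. A 3-carboxypropyl group at this position would help separate the two differences. So would a tetrazole chain that keeps the methyl branch.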